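Working notes: inverting the single stereocentre of compound 3

The compounds below may be only part of what the source reports. "The series", "measured", "known", "first", "only" and "open" are said of these compounds alone.

- compound 1 (`CCn1c(C(=O)NCCN)ccc1C(CC)(CC)c1ccc(OCS(=O)(=O)c2ccccc2)c(C)c1`) gives 6470 nM
- compound 2 (`CCN(CC)CCNC(=O)c1ccc(C(CC)(CC)c2ccc(OCS(=O)(=O)c3ccccc3)c(C)c2)n1CC`) gives 4680 nM
- compound 3 (`CCn1c(C(=O)N[C@@H](C)C(=O)O)ccc1C(CC)(CC)c1ccc(OCS(=O)(=O)c2ccccc2)c(C)c1`) gives 35500 nM

All three values come from a functional assay on MCF7 cells (Homo sapiens) for antiproliferative activity, read by MTT assay, with a stated time of 24 h (on this read-out higher numbers stand for weaker inhibition and lower numbers for stronger inhibition), and compound 3 has the highest number of the set. The measured steps to it are a 5.5-fold higher number from compound 1 to compound 3 (0.74 log units; beyond the scatter) and a 7.6-fold higher number from compound 2 to compound 3 (0.88 log units; beyond the scatter). By contrast, the step of a 1.4-fold lower number from compound 1 to compound 2 (0.14 log units; within the scatter) stays within the scatter.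

Compound 4 (`CCn1c(C(=O)N[C@H](C)C(=O)O)ccc1C(CC)(CC)c1ccc(OCS(=O)(=O)c2ccccc2)c(C)c1`) is the next structure. Against compound 3 the change is this: the two compounds have the same atoms and bonds and differ only in configuration as drawn: 1 of 1 stereo elements differ; a stereocentre at a saturated chain carbon is drawn S in compound 3 and R in compound 4; a stereocentre at a saturated chain carbon is drawn S in compound 3 and R in compound 4.

Going by the values given here, no measured pair tests configuration. The steps into compound 3 replace the whole group on the amide-type nitrogen, so they bear only loosely on this change and give no direction. They set a rough outer size, and a shift beyond the scatter is not expected in this assay. The expected step is a 1.1-fold lower number from compound 3 to compound 4 (0.05 log units; within the scatter). The estimate for compound 4 is 32000 nM, with an expected range of 13000 nM to 70000 nM.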

Compound 4, half-maximal inhibitory concentration: > 50000 nM
Compound 4: a limit, no number (the forecaster's own chance of this, stated with the estimate: 10%); middle value at least 1.5-fold (0.19 log units) from the limit.
By their numbers in this assay, from the lowest: compounds 2 and 1 (each within the scatter of the next); then compound 3. At a limit, above all of these: compound 4.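

In this assay compound 4 gives > 50000 nM, which is a limit and not a number. Going by these compounds alone, the S and R forms can now be compared for the first time, and inversion gives an at least 1.4-fold higher number from compound 3 to compound 4 (0.14 log units; that floor lies within the scatter), so the floor does not show that configuration at this saturated chain carbon matters, though it leaves room for a larger step: the fact that compounds 3 and 4 differ only in the configuration as drawn The 1-carboxyethyl group in the R form also stands apart from both amine-bearing chains, with an at least 10-fold higher number from compound 2 to compound 4 (1.02 log units; beyond the scatter) and an at least 7.7-fold higher number from compound 1 to compound 4 (0.88 log units; beyond the scatter), extending to this form the gap already seen with the S form.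

As far as these compounds go, the true size of the configuration step stays open while one member of the pair is a limit. Also open, from the compounds shown here alone, is whether the carboxylic acid itself goes with the higher numbers, which a methyl ester of the 1-carboxyethyl group or a longer chain ending in a carboxylic acid would test.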